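This account rests on a few compounds, and the source may have more. Where it says the series, first, only, none or still open, it means among the compounds named here.

Compound 1 `Oc1ccccc1-c1cc(-c2ccccc2)cc(-c2ccccc2O)n1` gives 8000 nM 
Compound 2 `Oc1cccc(-c2cc(-c3ccccc3)nc(-c3ccccc3)c2)c1` gives 17900 nM in the same test

In a functional assay on DU-145 cells (Homo sapiens) for cytotoxicity, read by ELISA, with a stated time of 2 days (a lower number here means a stronger inhibitor, a higher number a weaker inhibitor), compound 2 gives 17900 nM as the higher of the two numbers, beyond the scatter from compound 1. Compound 3 `Oc1cccc(-c2cc(-c3ccccc3)nc(-c3cccnc3)c2)c1` carries pyridin-3-yl in place of phenyl on an aromatic carbon. Within the data shown here, no measured pair shows this change, so in this assay only a small shift is expected, none beyond the scatter and with no firm direction. The expected step is a 1.2-fold lower number from compound 2 to compound 3 (0.08 log units; within the scatter) and stays within the scatter. Compound 3 is estimated at 15000 nM with an expected range from 6000 nM to 40000 nM in this measurement.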

Compound 3, half-maximal inhibitory concentration: 18900 nM
For compound 3 the middle estimate is 1.3-fold (0.10 log units) below the measured one; low and high end bracket the measured number.
By their numbers in this assay, from the lowest: compound 1; then compounds 2 and 3 (each within the scatter of the next).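

In this assay, pyridin-3-yl in place of phenyl on this aromatic carbon, next to the ring nitrogen, gives a 1.1-fold higher number from compound 2 to compound 3 (0.02 log units; within the scatter). The position therefore takes this ring nitrogen, and the hydrogen-bond acceptor that enters with it, with no shift that can be told from the scatter. Nothing shown here offers an explanation for this result.

The compounds shown leave open whether a carboxylic acid or an amine on the pyridin-3-yl ring would give a step beyond the scatter. They also leave open whether the same exchange at the remaining phenyl group would read the same.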